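A Carbamoyl Group Takes the Place of the Acid

The compounds below may be only part of what the source reports. "The series", "measured", "known", "first", "only" and "open" are said of these compounds alone.

Compound 1 `O=C(O)CNC(=O)Nc1ccc(F)c(C(F)(F)F)c1` was run in an ADME assay on microsomes from liver (Homo sapiens) for metabolic stability, using NADPH, with a stated time of 60 min; on this read-out lower numbers stand for slow clearance and higher numbers for fast clearance. In this assay compound 1 gives < 7 uL/min, which is a limit of the assay rather than a number. Compound 2 `CC(C)(C(=O)O)n1c(=O)[nH]c2cc(C(F)(F)F)c(F)cc21` gives < 7 uL/min in this assay, also a limit. The data so far show only (the limit of < 7 uL/min in this assay, at which 2 of the 2 values shown sit). Compound 3 `CC(C)(NC(=O)Nc1ccc(F)c(C(F)(F)F)c1)C(N)=O` differs from compound 1 by 1-carbamoyl-1-methylethyl in place of carboxymethyl on an amide-type nitrogen. Among the compounds with values here, no measured step between compounds is available to lean on, so the change is expected to raise clearance modestly, an expected step of an at least 1.4-fold higher number from compound 1 to compound 3 (0.15 log units; that floor lies within the scatter). Compound 3 is estimated at 10 uL/min, within a range from 5 uL/min to 25 uL/min.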

Compound 3, intrinsic clearance in a liver preparation (reported as CLH), per the amount of preparation that the assay uses: 19 uL/min
Compound 3: the middle estimate sits 1.9-fold (0.28 log units) below what was measured; low and high end bracket the measured number.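

On the amide-type nitrogen, 1-carbamoyl-1-methylethyl in place of carboxymethyl brings an at least 2.7-fold higher number from compound 1 to compound 3 (0.43 log units; beyond the scatter). As far as these compounds go, compound 1 gives a limit of the assay, so this step is a floor and its full size stays unknown. The change thus lifts the read-out clear of the limit in this assay, where the other compounds remain: the limit of < 7 uL/min in this assay, at which 2 of the 3 values shown sit.

The single change swaps the end group and branches the chain together, so the compounds shown do not separate the two. From the compounds shown here alone, how a carboxylic acid on the same branched chain would read in this assay remains open.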